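A few compounds are considered here, and "the series" means these few. Any claim that something is new, unique, unknown or untested is made for them only; others in the source may bear on it.

Measured compounds:
- compound 1, `C/N=C(\S)NCCCCn1nc(C)ccc1=O`: in a functional assay on the whole organism (stomach) with Rattus norvegicus as the target (a lower number here means that less compound is needed, a higher number that more compound is needed for the effect), compound 1 gives > 100 mg/kg, a limit of the assay and not a number.
- compound 2, `CC/N=C(\S)NCCCCCn1nc(-c2ccccc2)ccc1=O`: in this assay compound 2 gives 51.8 mg/kg.
- compound 3, `C/N=C(/NC#N)NCCCCCCn1nc(-c2ccccc2)ccc1=O`: in this assay compound 3 gives > 100 mg/kg, a limit of the assay and not a number.

Compound 3 therefore stands only at a limit in this assay; no measured number is known for it, and it shares that position with compound 1, since (the limit of > 100 mg/kg in this assay, at which 2 of the 3 values shown sit). Within the data shown here, the one measured step that leads to compound 3 is an at least 1.9-fold higher number from compound 2 to compound 3 (0.28 log units; that floor lies within the scatter), in which the thiourea-type group of compound 2 is exchanged for the cyanoguanidine-type group of compound 3.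

Compound 4, `CC/N=C(/NC#N)NCCCCCCn1nc(-c2ccccc2)ccc1=O`, keeps the cyanoguanidine of compound 3 and differs from it only by methyl in place of hydrogen on a saturated chain carbon bound to a double-bonded nitrogen. Among the measured compounds shown here, no measured step mirrors this change on its own: compound 1 carries the methyl and compound 2 the ethyl, but the two also differ in chain length and in the group on the shared core, so their two values show only that one sits at a limit and the other at a measured number.

With compound 3 already at a limit, and the step of an at least 1.9-fold higher number from compound 2 to compound 3 (0.28 log units; that floor lies within the scatter) pointing towards higher numbers for the cyanoguanidine, compound 4 is expected to stay near or at that limit, with a step that the limit leaves unreadable from compound 3 to compound 4. The estimate for compound 4 in this assay is 150 mg/kg, between 60 mg/kg and 400 mg/kg.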

Compound 4, dose for half-maximal effect: > 100 mg/kg
Compound 4 ended at the assay's limit (the forecaster's own chance of this, stated with the estimate: 70%); the middle value is on the limit's open side.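

In this assay compound 4 gives > 100 mg/kg, a limit of the assay and not a number, so methyl in place of hydrogen on a saturated chain carbon bound to a double-bonded nitrogen does not lift the cyanoguanidine-type group off that limit. The exchange of the thiourea-type group for the cyanoguanidine-type group can now be read a second time, as an at least 1.9-fold higher number from compound 2 to compound 4 (0.28 log units; that floor lies within the scatter), so this second reading, like the first, shows no change beyond the scatter. The step between compound 3 and compound 4 cannot be read, and the main new finding is that the values gather at one point: the limit of > 100 mg/kg in this assay, at which 3 of the 4 values shown sit.

From the compounds shown here alone, what methyl in place of hydrogen does at this position stays open, with no measured number on either side of the change. Also open, going by these compounds, is whether propyl or cyclopropyl in place of the ethyl of compound 4 would give a measured number with the cyanoguanidine-type group, as compound 2 gives 51.8 mg/kg with its thiourea-type group.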